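The source may report more compounds than this note shows. Statements on the series, on what has been measured and on what is new or still open speak of the compounds shown alone.

Measured compounds, an assay on CHO cells for displacement of a labelled ligand from adenosine receptor A3 (Homo sapiens), read by scintillation counting, with a stated time of 120 min, tested at 1 uM; a higher number here means more inhibition at the concentration tested (going by the name of the read-out), a lower number less inhibition:
- compound 1, `N#Cc1c(N)nc(SCc2ncn[nH]2)c(C#N)c1-c1ccc(OCC2CC2)cc1`: 1%
- compound 2, `N#Cc1c(N)nc(SCc2nnn[nH]2)c(C#N)c1-c1ccc(OCC2CC2)cc1`: 1%
- compound 3, `N#Cc1c(N)nc(SCC(N)=O)c(C#N)c1-c1ccc(OCC2CC2)cc1`: 8%

All three share one core and differ only in the group on the saturated chain carbon bound to the sulfur. Compound 1 and compound 2 sit at the same figure, no change at the digits printed from compound 1 to compound 2 (within the scatter). Compound 3 carries a carbamoyl group there and gives 8%; the gap from compound 1 is a number 7 percentage points higher from compound 1 to compound 3 (within the scatter), and from compound 2 it is a number 7 percentage points higher from compound 2 to compound 3 (within the scatter). For the measured compounds named here, every step so far lies within the scatter, so the three numbers describe one flat set with no resolved order.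

Compound 4, `COC(=O)CSc1nc(N)c(C#N)c(-c2ccc(OCC3CC3)cc2)c1C#N`, is the next member of the set and is to be measured in this assay. Relative to compound 1 the change is methoxycarbonyl in place of 1H-1,2,4-triazol-5-yl on a saturated chain carbon bound to a sulfur. Going by the values given here, the steps that bear on this are the exchange of a five-membered ring for a carbamoyl group, a number 7 percentage points higher from compound 1 to compound 3 (within the scatter) and a number 7 percentage points higher from compound 2 to compound 3 (within the scatter), and the ring-for-ring exchange no change at the digits printed from compound 1 to compound 2 (within the scatter); none moved the read-out beyond the scatter. For compound 4 a step of about a number 3 percentage points higher from compound 1 to compound 4 (within the scatter) is therefore expected, that is, no change beyond the scatter. Compound 4 is estimated at 4%, with a range from 0% to 14%.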

Compound 4, a percentage reported as inhibition, at one concentration (the size of the read-out at that concentration, not a potency): 1%
Compound 4: the middle estimate sits 3 percentage points above what was measured; the range from low to high includes it.
By their numbers in this assay, from the lowest: compounds 1, 2, 4 and 3 (each within the scatter of the next).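

In this assay, the set now includes a member with no ring and no hydrogen-bond donor on the saturated chain carbon bound to a sulfur, yet methoxycarbonyl does not separate from either five-membered ring (no change at the digits printed from compound 1 to compound 4 (within the scatter)) (no change at the digits printed from compound 2 to compound 4 (within the scatter)). The exchange on the carbonyl carbon itself, methoxy in place of amino, is the first change made at that atom, and it also stays unresolved (a number 7 percentage points lower from compound 3 to compound 4 (within the scatter)), so neither the ring nor the amino group is shown to matter for this read-out. Nothing at hand gives a reason for this flat behaviour.

The compounds shown leave open whether any group at this place can move the read-out beyond the scatter, for instance a carboxylic acid, a primary amine or a longer alkyl chain. With a single tested concentration, they also leave open whether the four compounds would still be indistinguishable at a higher concentration or in a full potency measurement.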